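Shortening an Ethyl to a Methyl: Expected Cell Tolerance

The compounds below may be only part of what the source reports. "The series", "measured", "known", "first", "only" and "open" are said of these compounds alone.

Of the compounds shown here, two of this set have been measured in a functional assay on RD cells (Homo sapiens) for inhibition, read by luminescence and ATP content, with a stated time of 72 h; a lower number here means that less compound is tolerated, a higher number that more compound is tolerated. Compound 1 `Cc1ccc(-c2ccc3ncc(-c4noc(C(F)(F)F)n4)cc3c2)cc1` gives > 22200 nM in this assay, a value that is a limit of the assay and not a number, as the line the limit of > 22200 nM in this assay, at which 1 of the 2 values shown sits, records. Compound 2 `CCc1ccc(-c2ccc3ncc(-c4noc(C)n4)cc3c2)cc1` gives > 7400 nM in this assay, again a limit rather than a number, as the line the limit of > 7400 nM in this assay, at which 1 of the 2 values shown sits, records. Among the measured compounds shown here, compound 2 therefore stands only at a limit, and the one other value shown for this assay is also a limit, so no ordering of the two compounds can be read from these numbers.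

Compound 3 `Cc1ccc(-c2ccc3ncc(-c4noc(C)n4)cc3c2)cc1` differs from compound 2 by one change: hydrogen in place of methyl on a saturated chain carbon bound to an aromatic carbon, or ethyl to methyl. For the measured compounds named here, no measured pair shows this change, so the expectation rests on compound 2 alone. The step that the limit leaves unreadable from compound 2 to compound 3 is expected to stay within the scatter of repeated measurements, with no direction favoured. Compound 3 is thus estimated at 20000 nM in this assay, within a range from 7000 nM to 60000 nM, most likely reported once more as a limit.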

Compound 3, half-maximal cytotoxic concentration: > 7400 nM
Compound 3: a limit, no number; the forecaster's own chance of this, stated with the estimate: 80%; the middle value does not contradict the limit.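

Compound 3 gives only a limit in this assay, as do compound 1 and compound 2, so neither step, from compound 1 or from compound 2 to compound 3, can be read. The compounds shown leave open the actual half-maximal cytotoxic concentration of each, and whether ethyl to methyl changes it at all.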